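The source may hold more compounds than are shown below. What is called first, only, known or untested is meant among the compounds shown, and "the series" means these compounds.

Measured compounds, each with its number in a functional assay on C8166 cells (Homo sapiens) for cytotoxicity, read by MTT assay; on this read-out lower numbers stand for higher toxicity in this test and higher numbers for lower toxicity in this test:

compound 1, `Cc1cc(S(N)(=O)=O)ccc1NC(=O)COc1ccc(Cl)cc1NC(=O)c1ccccc1[N+](=O)[O-]`: compound 1 gives 54800 nM
compound 2, `Cc1cc(S(N)(=O)=O)ccc1NC(=O)COc1ccc(Cl)cc1NC(=O)c1cccc(C(F)(F)F)c1`: compound 2 gives 124000 nM
compound 3, `Cc1ccc(C)c(C(=O)Nc2cc(Cl)ccc2OCC(=O)Nc2ccc(S(N)(=O)=O)cc2C)c1`: compound 3 gives 79700 nM

Compound 3 holds the second highest of the three numbers in this assay. Its nearest neighbour is compound 1, and the step of a 1.5-fold higher number from compound 1 to compound 3 (0.16 log units; within the scatter) sits within the scatter; the step of a 1.6-fold lower number from compound 2 to compound 3 (0.19 log units; within the scatter) also sits within the scatter. Across the whole set only one step moved beyond the scatter, a 2.3-fold higher number from compound 1 to compound 2 (0.35 log units; beyond the scatter), and that one was modest.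

Compound 4 is `Cc1cc(S(N)(=O)=O)ccc1NC(=O)COc1ccc(Cl)cc1NC(=O)c1cccc2ccccc12`. The change from compound 3 is naphthalen-1-yl in place of 2,5-dimethylphenyl on a carbonyl carbon.

All three measured steps vary the aryl group on this same carbonyl carbon, so all three bear on the change to compound 4. Two of them stayed within the scatter and the third was only modest. The expectation is therefore that compound 4 shows no step beyond the scatter in this assay: the estimated step is a 1.0-fold higher number from compound 3 to compound 4 (0.00 log units; within the scatter). Compound 4 is estimated at 80000 nM, with a range from 35000 nM to 180000 nM.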

Compound 4, half-maximal cytotoxic concentration: > 381000 nM
Compound 4 ended at the assay's limit (the forecaster's own chance of this, stated with the estimate: 15%); middle value at least 4.7-fold (0.67 log units) away from the limit.
By their numbers in this assay, from the lowest: compounds 1, 3 and 2 (each within the scatter of the next, the first and the last beyond it). At a limit, above all of these: compound 4.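

Compound 4 reads as a limit in this assay and not as a number: the limit of > 381000 nM in this assay, at which 1 of the 4 values shown sits.

The aryl group on this carbonyl carbon can therefore shift the read-out further than the single-ring groups showed, where the largest step was a 2.3-fold higher number from compound 1 to compound 2 (0.35 log units; beyond the scatter). Naphthalen-1-yl stands apart from all three of them, with an at least 4.7-fold higher number from compound 3 to compound 4 (0.67 log units; beyond the scatter) and an at least 3.0-fold higher number from compound 2 to compound 4 (0.48 log units; beyond the scatter) and an at least 6.9-fold higher number from compound 1 to compound 4 (0.84 log units; beyond the scatter), so the change points towards lower toxicity in this test, and each of these steps is a lower bound.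

Going by these compounds, the true size of these steps stays open, as does whether the second aromatic ring itself goes with the shift or only this particular attachment. Naphthalen-2-yl, cyclohexyl or a pyridine ring on the same carbonyl carbon would bear on that question.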